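The compounds below may be only part of what the source reports. "The series", "measured", "known", "first", "only" and "open" are said of these compounds alone.

- compound 1 `CC(C)c1ccc(Nc2ccc3c(OCCCN4CCN(C)CC4)cccc3n2)cc1`: 5650 nM
- compound 2 `CN1CCN(CCCOc2cccc3nc(Nc4ccc(F)c(F)c4)ccc23)CC1`: 660 nM
- compound 3 `CN1CCN(CCCOc2cccc3nc(Nc4cccc(Cl)c4)ccc23)CC1`: not yet measured

In a functional assay on UACC-257 cells (Homo sapiens) for inhibition, read by sulforhodamine B assay, with a stated time of 48 h (on this read-out higher numbers stand for weaker inhibition of growth and lower numbers for stronger inhibition of growth), compound 1 has the higher of the two measured numbers, at 5650 nM. Compound 3 differs from it in one place, with 3-chlorophenyl in place of 4-isopropylphenyl on a nitrogen on an aromatic ring. Among the compounds with values here, only one measured step bears on this change: an 8.6-fold lower number from compound 1 to compound 2 (0.93 log units; beyond the scatter). That step removes the same 4-isopropylphenyl, but a single step is thin evidence, so a similar or somewhat smaller drop is expected. The expected step is a 5.1-fold lower number from compound 1 to compound 3 (0.71 log units; beyond the scatter). The estimate for compound 3 is 1100 nM, with an expected range of 350 nM to 3500 nM.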

Compound 3, concentration for 50% growth inhibition: 1810 nM
Estimate against measurement, compound 3: 1.6-fold (0.22 log units) below, and the stated range covers the measured number.
By their numbers in this assay, from the lowest: compound 2; then compound 3; then compound 1.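

A second replacement of 4-isopropylphenyl also lowers the number, which here stands for stronger inhibition of growth (a 3.1-fold lower number from compound 1 to compound 3 (0.49 log units; beyond the scatter)), so the earlier drop is not unique to 3,4-difluorophenyl. The two replacements are not equal, as 3-chlorophenyl gives a weaker result than 3,4-difluorophenyl (a 2.7-fold higher number from compound 2 to compound 3 (0.44 log units; beyond the scatter)), so the choice of ring substituents on this nitrogen still matters. Nothing measured here explains these differences.

Still open, from the compounds shown here alone, is how an unsubstituted phenyl, a 3-fluorophenyl or a 4-aminophenyl would compare on this nitrogen.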